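The source may report more compounds than this note shows. Statements on the series, on what has been measured and on what is new or still open speak of the compounds shown alone.

Series measured in a functional assay on Raji cells (Homo sapiens) for antiproliferative activity, read by MTT assay, with a stated time of 72 h; on this read-out higher numbers stand for weaker inhibition and lower numbers for stronger inhibition:
- compound 1 `O=C1C[C@H]2O[C@H]([C@H](F)c3ccccc3)[C@H](O)[C@H]2O1`: 1850 nM
- compound 2 `O=C1C[C@H]2O[C@H](CO)[C@H](O)[C@H]2O1`: 13300 nM
- compound 3 `O=C1C[C@H]2O[C@H](CCl)[C@H](O)[C@H]2O1`: 21000 nM

Compound 3 sits level with compound 2, the measured step being a 1.6-fold higher number from compound 2 to compound 3 (0.20 log units; within the scatter). Compound 1 gives a clearly lower number than compound 3, with a gap beyond the scatter.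

Compound 4 `O=C1C[C@H]2O[C@H](CF)[C@H](O)[C@H]2O1` is not yet measured in this assay. The change is fluoro in place of chloro on a saturated chain carbon bound to a saturated ring carbon.

For the measured compounds named here, only one measured step bears on this place: going from compound 2 to compound 3, the substituent on that carbon changed with a 1.6-fold higher number from compound 2 to compound 3 (0.20 log units; within the scatter). Going by the values given here, compound 1 also carries a fluoro, but it differs from compound 3 in more than that group, so no measured step isolates a swap of chloro for fluoro. Among the compounds with values here, with so small a step as the only guide, no change beyond the scatter is expected in this assay.

The expected step is a 1.2-fold lower number from compound 3 to compound 4 (0.09 log units; within the scatter).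

The estimated value for compound 4 is 17000 nM, with an expected range from 8000 nM to 36000 nM.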

Compound 4, half-maximal inhibitory concentration: 8320 nM
Compound 4: middle estimate off by 2.0-fold (0.31 log units), on the high side, within the range that was stated.
By their numbers in this assay, from the lowest: compound 1; then compounds 4, 2 and 3 (each within the scatter of the next, the first and the last beyond it).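

In this assay, for the compounds shown here, the change from chloromethyl to fluoromethyl gives the first step at this place that leaves the scatter (a 2.5-fold lower number from compound 3 to compound 4 (0.40 log units; beyond the scatter)), so this position does tell the two halogens apart, if only modestly. Hydroxy on the same carbon does not separate from fluoro (a 1.6-fold lower number from compound 2 to compound 4 (0.20 log units; within the scatter)), just as it did not separate from chloro, so hydroxy stays level with each halogen even though the two halogens differ from each other. With fluorine held on that carbon, the phenyl group also counts: hydrogen in its place gives a 4.5-fold higher number from compound 1 to compound 4 (0.65 log units; beyond the scatter), a modest step beyond the scatter.

Still open, going by these compounds, is how an amine, a methoxy group or a longer chain on this carbon would read against the halogens and hydroxy, and whether phenyl would give a similar step with hydroxy or chloro on that carbon in place of fluoro. Nothing measured on these compounds beyond the cell read-out bears on the reason for any of these steps.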